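Amide aryl variation on the shared core

The source may report more compounds than this note shows. Statements on the series, on what has been measured and on what is new or still open speak of the compounds shown alone.

Measured compounds:
compound 1 `O=C(Nc1cccc(-c2oc3cc(-c4ccc(F)cc4)ccc3c(=O)c2O)c1)c1ccccc1F` gives 10100 nM in a functional assay on HepG2 cells (Homo sapiens) for antiproliferative activity, read by CCK-8 assay, with a stated time of 72 h; a higher number here means a weaker inhibitor, a lower number a stronger inhibitor
compound 2 `COc1ccc(C(=O)Nc2cccc(-c3oc4cc(-c5ccc(F)cc5)ccc4c(=O)c3O)c2)cc1` gives 8420 nM in this assay
compound 3 `COc1cccc(C(=O)Nc2cccc(-c3oc4cc(-c5ccc(F)cc5)ccc4c(=O)c3O)c2)c1` gives 9950 nM in this assay

Compound 1 has the highest of the three numbers, but both neighbours lie within the scatter of it. The unmeasured compound 4 `Cc1cc(C(=O)Nc2cccc(-c3oc4cc(-c5ccc(F)cc5)ccc4c(=O)c3O)c2)ccc1F` differs from compound 1 in one place: 4-fluoro-3-methylphenyl in place of 2-fluorophenyl on a carbonyl carbon. The two measured steps that change the aryl on the same carbonyl carbon, a 1.2-fold lower number from compound 1 to compound 2 (0.08 log units; within the scatter) and a 1.0-fold lower number from compound 1 to compound 3 (0.01 log units; within the scatter), were both within the scatter, and no change at this position has yet moved the number. A step of a 1.1-fold lower number from compound 1 to compound 4 (0.03 log units; within the scatter) is therefore expected, that is none beyond the scatter. Compound 4 is estimated at 9500 nM, with a range from 5000 nM to 19000 nM in this assay.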

Compound 4, half-maximal inhibitory concentration: 9540 nM
Compound 4: the middle estimate sits 1.0-fold (0.00 log units) below what was measured; the range from low to high includes it.
By their numbers in this assay, from the lowest: compounds 2, 4, 3 and 1 (each within the scatter of the next).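

With 4-fluoro-3-methylphenyl on the carbonyl carbon, the steps in this assay read a 1.1-fold lower number from compound 1 to compound 4 (0.02 log units; within the scatter) and a 1.0-fold lower number from compound 3 to compound 4 (0.02 log units; within the scatter) and a 1.1-fold higher number from compound 2 to compound 4 (0.05 log units; within the scatter) and all lie within the scatter. Within the data shown here, a methyl and a fluorine on the same ring therefore leave the number as flat as the single fluoro and methoxy groups did, so all four aryl groups at this position stand within the scatter of one another. No available evidence bears on why this position is so flat.

Every group shown here is a substituted phenyl. From the compounds shown here alone, whether an amine or a carboxylic acid on that ring, or a longer chain in its place, would move the number remains open.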